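The source may report more compounds than this note shows. Statements on the series, on what has been measured and on what is new or still open speak of the compounds shown alone.

Measured compounds:
compound 1 `Cc1cc(C)nc(Oc2ccc(NC(=O)Nc3ccc(OC(F)(F)F)cc3)cc2)n1` — 30800 nM
compound 2 `Cc1cc(C)nc(Sc2ccc(NC(=O)Nc3ccccc3)cc2)n1` — 22000 nM

Of the compounds shown here, two have so far been measured in a functional assay on CNE-2 cells (Homo sapiens) for cytotoxicity, read by MTT assay, with a stated time of 3 days; a higher number here means a weaker inhibitor, a lower number a stronger inhibitor. Compound 1 `Cc1cc(C)nc(Oc2ccc(NC(=O)Nc3ccc(OC(F)(F)F)cc3)cc2)n1` gives 30800 nM. Compound 2 `Cc1cc(C)nc(Sc2ccc(NC(=O)Nc3ccccc3)cc2)n1` gives 22000 nM. Of the two numbers, compound 2 has the lower one, yet the gap to compound 1 lies within the scatter of repeated measurements, so the two cannot be told apart on this evidence; both sit at a weak level in this assay.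

Compound 3 `Cc1cccc(NC(=O)Nc2ccc(Sc3nc(C)cc(C)n3)cc2)c1` has not yet been measured. It differs from compound 2 in a single place: methyl in place of hydrogen on an aromatic carbon, a methyl in place of hydrogen on an aromatic carbon, meta to a large group. Among the measured compounds shown here, no pair of measured compounds in this set shows the effect of such a change, so there is no measured step to lean on. Adding a single carbon with no donor or acceptor to a compound that already sits at a weak level gives little ground to expect a move beyond the scatter. Compound 3 is therefore expected to land near compound 2, the step of a 1.1-fold lower number from compound 2 to compound 3 (0.04 log units; within the scatter) being estimated as small and without a clear direction. The estimate for compound 3 in this assay is 20000 nM, with a range from 8000 nM to 50000 nM.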

Compound 3, half-maximal inhibitory concentration: > 50000 nM
Compound 3 was reported as a limit; the forecaster's own chance of this, stated with the estimate: 15%; at least 2.5-fold (0.39 log units) between middle value and limit.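

In this assay compound 3 gives > 50000 nM, which is a limit of the assay and not a number. Among the compounds shown here, the change from phenyl to 3-methylphenyl still yields the first readable step in this set, an at least 2.2-fold higher number from compound 2 to compound 3 (0.35 log units; beyond the scatter), and so shows that this position, on an aromatic carbon and meta to a large group, does not tolerate even a single added methyl without a measurable move toward the weaker end. The step's true size remains unknown, since the reading fixes only its lower end: the limit of > 50000 nM in this assay, at which 1 of the 3 values shown sits.

The compounds shown leave open whether the same move would follow from a chlorine, a fluorine, a methoxy group or an amine at this place, or from a methyl on another carbon of the same ring, so one step cannot yet be called a trend for the position. Compound 1 differs from compound 2 in more than one place, which leaves the separate contributions of its trifluoromethoxy group and of its oxygen link in place of sulfur unread.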